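Replacing a Chlorobenzyl Arm with a Thiourea Arm

The source may hold more compounds than are shown below. What is called first, only, known or untested is meant among the compounds shown, and "the series" means these compounds.

Of the compounds shown here, three built on one shared core have been tested in a functional assay on HeLa cells (Homo sapiens) for antiproliferative activity, with a stated time of 24 h; a lower number here means a stronger inhibitor, a higher number a weaker inhibitor. Compound 1 `NC(=O)c1c(NC(=O)c2ccccc2Cl)sc2c1CCN(Cc1ccc(Cl)cc1)C2` gives only a limit there, > 50000 nM, not a measured number. Compound 2 `NC(=O)c1c(NC(=O)c2ccccc2F)sc2c1CCN(Cc1cccc(Cl)c1)C2` gives 49500 nM in this assay. Compound 3 `NC(=O)c1c(NC(=O)c2ccccc2F)sc2c1CCN(Cc1c(Cl)cccc1Cl)C2` gives 33000 nM in this assay. Within the data shown here, the one step between these measured compounds that differs in a single place, a 1.5-fold lower number from compound 2 to compound 3 (0.18 log units; within the scatter), shows that swapping one chlorophenyl pattern for another on that ring nitrogen changes little. Compound 1 stands at the edge of what the assay can report, as the limit of > 50000 nM in this assay, at which 1 of the 3 values shown sits, shows, so all three compounds are weak inhibitors of the same order.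

Compound 4 `COc1ccc(NC(=S)N2CCc3c(sc(NC(=O)c4ccccc4Cl)c3C(N)=O)C2)cc1` differs from compound 1 as follows: a group of 11 heavy atoms (8 carbon, 1 nitrogen, 1 oxygen, 1 sulfur; one six-membered aromatic ring of carbon only) in place of a group of 8 heavy atoms (7 carbon, 1 chlorine; one six-membered aromatic ring of carbon only), on an amine nitrogen in a ring. Among the measured compounds shown here, no measured step tests this kind of replacement; the only measured step swaps one chlorophenyl for another and lies within the scatter. For the measured compounds named here, the step into compound 4 is larger in kind, yet nothing among the measured compounds points in either direction. Compound 4 is therefore expected to give 40000 nM, with a likely range from 10000 nM to 150000 nM. That estimate means a step of an at least 1.2-fold lower number from compound 1 to compound 4 (0.09 log units; that floor lies within the scatter), with a real chance that only a limit is reported again.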

Compound 4, half-maximal inhibitory concentration: 36400 nM
Estimate against measurement, compound 4: 1.1-fold (0.04 log units) above; the range from low to high includes it.
By their numbers in this assay, from the lowest: compounds 3, 4 and 2 (each within the scatter of the next). At a limit, above all of these: compound 1.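

The earlier compounds shown here only exchanged one chlorophenyl pattern for another on this ring nitrogen, whereas this change puts a thiourea arm, with a hydrogen-bond donor, hydrogen-bond acceptors and a double bond outside aromatic rings, in place of the 4-chlorobenzyl group. Even so, the result in this assay is an at least 1.3-fold lower number from compound 1 to compound 4 (0.13 log units; that floor lies within the scatter), so this much larger replacement on the amine nitrogen in a ring gives no sign of a real gain, although a measured number now takes the place of a limit. The true size of the step cannot be fixed because compound 1 has no measured number, only a limit: the limit of > 50000 nM in this assay, at which 1 of the 4 values shown sits.

The compounds shown contain no step at this nitrogen that lies beyond the scatter, so it remains open whether any group placed there can move the number clearly in either direction. An arm ending in an amine or a carboxylic acid, or a urea with oxygen in place of the sulfur, would test whether this position matters for antiproliferative activity at all.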